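Shifting one methoxy group: from compound 3 to compound 4

This account rests on a few compounds, and the source may have more. Where it says the series, first, only, none or still open, it means among the compounds named here.

Measured in a functional assay on MCF7 cells (Homo sapiens) for antiproliferative activity, read by MTT assay, with a stated time of 72 h; a lower number here means a stronger inhibitor, a higher number a weaker inhibitor:
- compound 1 `COc1cc(-c2ncnn2-c2cccc(F)c2)cc(OC)c1OC`: > 10000 nM, a limit
- compound 2 `COc1cc(-c2ncnn2-c2ccc(Cl)cc2Cl)cc(OC)c1OC`: > 10000 nM, a limit
- compound 3 `COc1ccc(-c2ncnn2-c2cc(OC)c(OC)c(OC)c2)cc1`: 360 nM

For the measured compounds named here, compound 3 holds the only number in this small set, since the results for compound 1 and compound 2 are limits and cannot be ranked against it as numbers.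

The next compound to read is compound 4 `COc1cccc(-c2ncnn2-c2cc(OC)c(OC)c(OC)c2)c1`, which has the same atoms as compound 3, joined differently: 3-methoxyphenyl in place of 4-methoxyphenyl on an aromatic carbon. The exchange sits on an aromatic carbon of a five-membered aromatic ring with 3 nitrogen.

Going by the values given here, the only measured step, a step that the two limits leave unreadable from compound 1 to compound 2, offers no size to carry over, and it concerns a different group, on an aromatic nitrogen. Among the compounds with values here, no measured step moves a methoxy group. The expectation therefore has two anchors only. The first is compound 3 at 360 nM. The second is the limit of > 10000 nM in this assay, at which 2 of the 3 values shown sit.

A loss of potency is expected, with wide uncertainty, and a reading at the limit would not be surprising. The step expected in this assay is a 6.9-fold higher number from compound 3 to compound 4 (0.84 log units; beyond the scatter), towards weaker inhibition. For compound 4 the estimated value is 2500 nM, with an expected range of 400 nM to 10000 nM.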

Compound 4, half-maximal inhibitory concentration: > 10000 nM
Compound 4: no number, only a limit; the forecaster's own chance of this, stated with the estimate: 25%; middle value at least 4.0-fold (0.60 log units) from the limit.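

In this assay, for the compounds shown here, the first readable step is a purely positional change with no atoms gained or lost: 3-methoxyphenyl in place of 4-methoxyphenyl gives an at least 27-fold higher number from compound 3 to compound 4 (1.44 log units; beyond the scatter). Compound 4 gives > 10000 nM, which is a limit and not a number. Going by these compounds alone, the result shows that, on an aromatic carbon of a five-membered aromatic ring with 3 nitrogen, activity depends on how the methoxyphenyl group is joined and not only on its atoms, and compound 3 remains the only compound here with a number: the limit of > 10000 nM in this assay, at which 3 of the 4 values shown sit.

Open, from the compounds shown here alone, is whether the methoxy group of 4-methoxyphenyl is itself required, or whether a hydroxyl, an ethoxy group or an amine in its place on the phenyl ring would also give a number in this assay. Also open, going by these compounds, is how far compound 4 actually lies from compound 3, since the size of that step is bounded only on one side.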